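This account rests on a few compounds, and the source may have more. Where it says the series, first, only, none or still open, it means among the compounds named here.

Compound 1 `CCN1CCN(c2cc(C)c3cc(NC(=O)c4ccc(C)cc4)ccc3n2)CC1` carries a 4-methylphenyl group on the amide carbonyl of a shared core. Going by the values given here, in a functional assay on MCF7 cells (Homo sapiens) for antiproliferative activity, read by MTT assay, with a stated time of 72 h (a higher number here means a weaker inhibitor, a lower number a stronger inhibitor), compound 1 gives 6740 nM, the highest of the two numbers measured so far. Among the compounds with values here, the only other measured compound, compound 2 `Cc1cc(NCCN2CCCCC2)nc2ccc(NC(=O)c3ccc(Cl)c(Cl)c3)cc12`, differs from compound 1 in several places at once; in this assay compound 2 gives 1190 nM, a lower number, beyond the usual scatter. Compound 3 `CCN1CCN(c2cc(C)c3cc(NC(=O)c4cccc(F)c4)ccc3n2)CC1` has not yet been measured. It differs from compound 1 in one place: 3-fluorophenyl in place of 4-methylphenyl on a carbonyl carbon. Within the data shown here, no measured pair mirrors this change, so nothing measured points a direction. The expected step is small, a 1.3-fold lower number from compound 1 to compound 3 (0.13 log units; within the scatter), perhaps toward a somewhat lower number, and possibly no larger than the scatter. Compound 3 is therefore estimated at 5000 nM in this assay, with a range from 1500 nM to 15000 nM.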

Compound 3, half-maximal inhibitory concentration: 8920 nM
Estimate against measurement, compound 3: 1.8-fold (0.25 log units) below, and the stated range covers the measured number.
By their numbers in this assay, from the lowest: compound 2; then compounds 1 and 3 (each within the scatter of the next).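

Putting 3-fluorophenyl in place of 4-methylphenyl on a carbonyl carbon gives a 1.3-fold higher number from compound 1 to compound 3 (0.12 log units; within the scatter) in this assay. Going by these compounds alone, this is the first comparison in which only this group changes, and it shows that this particular exchange, which removes a methyl group and adds a fluorine atom on the phenyl ring, produces no difference that can be separated from ordinary repeat variation. No supporting measurement is available to explain this result.

A single exchange between two substituted phenyl groups says little about the position as a whole. On these data alone, it remains open whether a quite different group on the carbonyl carbon, such as a pyridine ring, a phenyl ring bearing an amine or carboxylic acid, or a longer alkyl chain, would shift the number beyond the scatter.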